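This account rests on a few compounds, and the source may have more. Where it says the series, first, only, none or still open, it means among the compounds named here.

Measured compounds:
compound 1 `C=CCOc1ccc2c(NCCCN(C)C)ccnc2c1`: 6680 nM
compound 2 `CC(C)COc1ccc2c(Cl)ccnc2c1`: 3030 nM

In a functional assay on BGC-823 cells (Homo sapiens) for cytotoxicity, read by MTT assay, with a stated time of 48 h (on this read-out lower numbers stand for stronger inhibition and higher numbers for weaker inhibition), compound 1 gives 6680 nM, the higher of the two numbers recorded so far. Compound 2 gives 3030 nM, a lower number, and the gap between the two lies beyond the usual scatter. These two compounds differ in more than one place, so no single structural step can be read from them.

Compound 3 `CCOc1ccc2c(NCCCN(C)C)ccnc2c1` has not yet been measured. It differs from compound 1 by methyl in place of vinyl on a saturated chain carbon bound to an oxygen on an aromatic ring. For the measured compounds named here, no step of this kind is recorded, so the expectation rests on the small size of the change alone. In this assay the expected step is a 1.1-fold lower number from compound 1 to compound 3 (0.05 log units; within the scatter), which is none beyond the scatter and without a clear direction. Compound 3 is therefore estimated at 6000 nM, within a range of 2500 nM to 15000 nM.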

Compound 3, half-maximal inhibitory concentration: 9810 nM
Compound 3: middle estimate off by 1.6-fold (0.21 log units), on the low side, within the range that was stated.
By their numbers in this assay, from the lowest: compound 2; then compounds 1 and 3 (each within the scatter of the next).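

In this assay, the first step recorded at this position, allyloxy to ethoxy, is a 1.5-fold higher number from compound 1 to compound 3 (0.17 log units; within the scatter). The loss of one carbon and of the double bond outside aromatic rings therefore leaves the number within the scatter, and this pair gives no sign that the vinyl end matters to the read-out. No measured property of either compound bears on this step.

One pair cannot show how far this position tolerates change: a phenyl or a longer chain on the saturated chain carbon bound to an oxygen on an aromatic ring could still move the number beyond the scatter. Also open, going by these compounds, is whether allyl to ethyl reads the same on a core carrying a piperazine in place of the dimethylaminopropylamine chain.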